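A few compounds are considered here, and "the series" means these few. Any claim that something is new, unique, unknown or untested is made for them only; others in the source may bear on it.

Among the measured compounds shown here, in a functional assay on KG-1 cells (Homo sapiens) for inhibition, read by MTT assay, with a stated time of 48 h (on this read-out higher numbers stand for weaker inhibition and lower numbers for stronger inhibition), compound 2 (`O=C(CCCCCNC(=O)Cn1cnc2c(Nc3ccccc3)nc(Nc3ccccc3)nc21)NO`) gives 3800 nM, the only actual number among the values shown. Compound 1 (`O=C(CCCCCNC(=O)Cn1cnc2c(Nc3ccccc3)ncnc21)NO`) gives > 50000 nM, which is a limit. Compound 3 (`O=C(CCCCNC(=O)Cn1cnc2c(Nc3ccccc3)ncnc21)NO`) gives > 50000 nM, which is also a limit. The large step of an at least 13-fold lower number from compound 1 to compound 2 (1.11 log units; beyond the scatter) comes with anilino in place of hydrogen on an aromatic carbon, not with a change in the chain. Compound 4 (`O=C(CCCCCCNC(=O)Cn1cnc2c(Nc3ccccc3)nc(Nc3ccccc3)nc21)NO`) differs from compound 2 in the chain alone: (hydroxycarbamoyl)methyl in place of hydroxycarbamoyl on a saturated chain carbon, five bonds along the chain from an amide-type nitrogen. For the measured compounds named here, the only chain step, a step that the two limits leave unreadable from compound 1 to compound 3, offers no size to carry over, so no shift beyond the scatter is expected in this assay. The expected result is a 1.1-fold lower number from compound 2 to compound 4 (0.04 log units; within the scatter). For compound 4 the estimated value is 3500 nM, with an expected range of 1000 nM to 14000 nM.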

Compound 4, half-maximal inhibitory concentration: 2880 nM
Estimate against measurement, compound 4: 1.2-fold (0.08 log units) above; low and high end bracket the measured number.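

In this assay the change to (hydroxycarbamoyl)methyl at this chain position gives a 1.3-fold lower number from compound 2 to compound 4 (0.12 log units; within the scatter) and so, with the second anilino group present, the two chain lengths read alike. Among the compounds shown here, this is the first chain change with a readable size, as the earlier one could not be read: the limit of > 50000 nM in this assay, at which 2 of the 4 values shown sit.

On these data alone, whether a longer chain than that of compound 4 would read the same stays open. So does what a carboxylic acid or an amine in place of hydroxycarbamoyl would give.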